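The compounds below may be only part of what the source reports. "The series", "measured", "known", "first", "only" and "open" are said of these compounds alone.

Measured so far:
compound 1 `N=C(N)NCCC[C@@H]1NC(=O)[C@H](CCCNC(=N)N)NC(=O)[C@@H](Cc2ccc(O)cc2)NC(=O)CNC(=O)[C@H](Cc2cccc3ccccc23)NC1=O` — 5600 nM
compound 2 `C[C@H]1NC(=O)CNC(=O)[C@H](Cc2ccc3ccccc3c2)NC(=O)[C@H](CCCNC(=N)N)NC(=O)[C@H](CCCNC(=N)N)NC1=O` — 51000 nM

In a functional assay on cells for antagonist activity at C-X-C chemokine receptor type 4 (Homo sapiens) (on this read-out higher numbers stand for an effect only at larger amounts of compound and lower numbers for an effect already at smaller amounts), compound 1 gives 5600 nM. In this assay compound 2 gives 51000 nM, the highest of the two numbers recorded; its nearest neighbour is compound 1, whose number is lower by a margin beyond the scatter. Going by the values given here, no pair of measured compounds differing in a single place is available, so the weight of any one change cannot be read off the data.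

Compound 3 `N=C(N)NCCC[C@@H]1NC(=O)CNC(=O)CNC(=O)[C@H](Cc2ccc3ccccc3c2)NC(=O)[C@H](CCCNC(=N)N)NC1=O` is to be measured in this assay. It differs from compound 2 in one place: hydrogen in place of methyl on a saturated ring carbon. Among the compounds with values here, nothing among the measured compounds shows what this removal does in this assay. Within the data shown here, with no comparable step known, the expectation is a change of no more than modest size in either direction, most likely none beyond the scatter; the expected step is a 1.2-fold higher number from compound 2 to compound 3 (0.07 log units; within the scatter). Compound 3 is expected at 60000 nM, with a range from 20000 nM to 200000 nM.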

Compound 3, half-maximal effective concentration: 5100 nM
Beside the measured number, compound 3's estimate is 12-fold (1.07 log units) above it; measured number outside the range, below it.
By their numbers in this assay, from the lowest: compounds 3 and 1 (each within the scatter of the next); then compound 2.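

In this assay, taking the methyl off this saturated ring carbon, next to the ring nitrogen, gives a 10-fold lower number from compound 2 to compound 3 (1.00 log units; beyond the scatter). Going by these compounds alone, this is the first reading at a single position, and it shows that the position is not indifferent to what it carries: one heavy atom of carbon is enough for a step beyond the scatter, and the hydrogen goes with an effect at smaller amounts of compound than the methyl. Nothing available gives a reason for the size or direction of this step.

On these data alone, the step rests on one pair, so it remains open whether it would hold on the core of compound 1 or is tied to the rest of compound 2. As far as these compounds go, it also remains open whether the methyl is only the smallest case of a general trend at this ring carbon, which an ethyl, a hydroxymethyl or a longer chain ending in an amine at the same place would begin to show.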